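The compounds below may be only part of what the source reports. "The series", "measured", "known", "first", "only" and "open" are said of these compounds alone.

Measured compounds:
- compound 1, `CCOC(=O)C1CCN(S(=O)(=O)c2ccc(S(=O)(=O)N(CC)CC)cc2)CC1`, 27200 nM
- compound 2, `CCN(CC)S(=O)(=O)c1ccc(S(=O)(=O)N2CCC[C@@H](C(=O)NC3CN(C(=O)C4CC4)C3)C2)cc1`, 2800 nM
- compound 3, `CCN(CC)S(=O)(=O)c1ccc(S(=O)(=O)N2CCC[C@@H](C(=O)NC3CCN(C(=O)OC(C)(C)C)CC3)C2)cc1`, 100 nM

All three numbers come from a functional assay on MIA PaCa-2 cells (Homo sapiens) for inhibition, read by MTT assay, with a stated time of 7 days; a higher number here means a weaker inhibitor, a lower number a stronger inhibitor. Compound 2 stands second highest of the three. Compound 1 gives a higher number than compound 2, and that gap lies beyond the usual scatter of repeated measurements. Compound 3 gives a lower number than compound 2, and that gap too lies beyond the scatter, so on these numbers compound 2 sits between a weaker and a stronger inhibitor.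

Compound 4, `CCN1CC(NC(=O)[C@@H]2CCCN(S(=O)(=O)c3ccc(S(=O)(=O)N(CC)CC)cc3)C2)C1`, has not yet been measured. It differs from compound 2 in one place: ethyl in place of cyclopropylcarbonyl on an amine nitrogen in a ring. The shared core, both sulfonyl groups and the amide link stay as they are.

Among the compounds with values here, no measured pair in this set shows what such a swap does, so the direction of the step is open. The expectation is for a number near that of compound 2, with a modest move toward a weaker inhibitor judged more likely than a move the other way; the step from a 1.4-fold higher number from compound 2 to compound 4 (0.15 log units; within the scatter) is the estimated outcome. Compound 4 is therefore expected to give about 4000 nM, within a range from 1000 nM to 15000 nM.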

Compound 4, half-maximal inhibitory concentration: > 30000 nM
Compound 4 ended at the assay's limit; the forecaster's own chance of this, stated with the estimate: 10%; middle value at least 7.5-fold (0.87 log units) from the limit.
By their numbers in this assay, from the lowest: compound 3; then compound 2; then compound 1. At a limit, above all of these: compound 4.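

In this assay, this is the first change in one place among the compounds shown, and it reveals that the group on the amine nitrogen of the four-membered non-aromatic ring strongly affects the read-out. Replacing cyclopropylcarbonyl with ethyl at this nitrogen gives an at least 10-fold higher number from compound 2 to compound 4 (1.02 log units; beyond the scatter), a large step beyond the usual scatter. Compound 4 gives > 30000 nM, which is a limit of the assay and not a number: the limit of > 30000 nM in this assay, at which 1 of the 4 values shown sits.

The change removes the carbonyl and the three-membered ring together, so this single step cannot separate the contribution of either part. It also leaves open whether an acetyl group, which keeps the carbonyl without that ring, or a cyclopropyl group, which keeps that ring without the carbonyl, would stay nearer to compound 2 in this assay.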